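This account rests on a few compounds, and the source may have more. Where it says the series, first, only, none or still open, it means among the compounds named here.

Measured so far in a functional assay on HT-29 cells (Homo sapiens); a higher number here means that more compound is needed for the effect, a lower number that less compound is needed:
- compound 1 `CS(=O)(=O)Nc1ccc(-c2cc(C(=O)N[C@H]3CCCNC3)c(NC(N)=O)s2)cc1`: 2200 nM
- compound 2 `NC(=O)Nc1sc(-c2ccc(C(N)=O)cc2)cc1C(=O)N[C@H]1CCCNC1`: 3200 nM

Within the data shown here, compound 2, at 3200 nM, cannot be separated from the only other measured compound. The gap between them is a 1.5-fold higher number from compound 1 to compound 2 (0.16 log units; within the scatter).

The next compound is compound 3 `CN(C)c1ccc(-c2cc(C(=O)N[C@H]3CCCNC3)c(NC(N)=O)s2)cc1`, which has dimethylamino in place of carbamoyl on an aromatic carbon, para to a large group, with the rest of compound 2 unchanged: dimethylamino in place of carbamoyl on an aromatic carbon. Its value in this assay is not yet known.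

Among the measured compounds shown here, one measured step bears on this change, since it concerns the same place on the molecule: a 1.5-fold higher number from compound 1 to compound 2 (0.16 log units; within the scatter). Exchanging methanesulfonamido for carbamoyl there left the number within the scatter. For the measured compounds named here, no measured compound carries dimethylamino, however, and two compounds offer only thin evidence, so the range has to stay wide. No step beyond the scatter is expected, and no direction can be supported with confidence.

The estimate means a 1.3-fold lower number from compound 2 to compound 3 (0.11 log units; within the scatter), an expected step that stays small. Compound 3 is expected at 2500 nM, with an estimated range of 800 nM to 8000 nM.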

Compound 3, half-maximal effective concentration: 90 nM
The estimate for compound 3 lay 28-fold (1.44 log units) above the measured number; the whole stated range lies above it.
By their numbers in this assay, from the lowest: compound 3; then compounds 1 and 2 (each within the scatter of the next).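

In this assay, the group on this aromatic carbon proves able to move the number strongly: dimethylamino in place of carbamoyl gives a 36-fold lower number from compound 2 to compound 3 (1.55 log units; beyond the scatter) and dimethylamino in place of methanesulfonamido gives a 24-fold lower number from compound 1 to compound 3 (1.39 log units; beyond the scatter) as well. The earlier exchange of methanesulfonamido for carbamoyl, a 1.5-fold higher number from compound 1 to compound 2 (0.16 log units; within the scatter) at this same place, gave no hint of such sensitivity, so compound 3 now stands clearly apart from both other compounds. Carbamoyl has a hydrogen-bond donor and dimethylamino has none, but that count is only one of several differences between the two groups, and no measurement here gives a reason for the large step.

Going by these compounds, whether the step depends on the amine nitrogen, on its two methyl groups or on the loss of the carbonyl remains open. A primary amino group, a methoxy group or a morpholine ring on this same carbon would begin to separate these readings, and a single compound cannot show how far the gain extends to other groups.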